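The compounds below may be only part of what the source reports. "The series", "measured", "known", "first", "only" and "open" are said of these compounds alone.

Compound 1 `Cc1ccccc1C(=O)NC(CCN(C)C)c1ccc(Cl)cc1` gives 175% in an assay on NIH3T3 cells with Urotensin-2 receptor (Homo sapiens) as the target; a higher number here means a larger maximal response, a lower number a smaller maximal response.
Compound 2 `COc1ccc(C(=O)NC(CCN(C)C)c2ccc(Cl)cc2)cc1` gives 162% in this assay.
Compound 3 `CN(C)CCC(NC(=O)c1ccccc1)c1ccc(Cl)cc1` gives 158% in this assay.

Compound 3 stands at the low end of the three numbers. Its nearest neighbour is compound 2, and the step of a number 4 percentage points lower from compound 2 to compound 3 (within the scatter) lies within the usual scatter, so the two cannot be ranked against each other. The furthest is compound 1, and the step of a number 17 percentage points lower from compound 1 to compound 3 (beyond the scatter) is beyond the scatter.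

Compound 4 `CN(C)CCC(NC(=O)NCc1ccccc1)c1ccc(Cl)cc1` differs from compound 3 in a single place: benzylamino in place of phenyl on a carbonyl carbon. Among the compounds with values here, none of the measured steps changes the group on the carbonyl carbon in this way; they only alter what sits on the phenyl there, as in a number 13 percentage points lower from compound 1 to compound 2 (beyond the scatter) and a number 17 percentage points lower from compound 1 to compound 3 (beyond the scatter), both modest. The change to benzylamino is therefore not directly covered, and only a modest step in this assay is expected, with uncertain direction. Compound 4 is estimated at 150%, in the range 120% to 180%, which means an expected step of a number 8 percentage points lower from compound 3 to compound 4 (within the scatter).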

Compound 4, largest response reached (reported as efficacy), in percent of the reference or control that the assay uses: 179%
Compound 4: middle estimate off by 29 percentage points, on the low side, and the stated range covers the measured number.
By their numbers in this assay, from the lowest: compounds 3 and 2 (each within the scatter of the next); then compounds 1 and 4 (each within the scatter of the next).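

The measured steps had only altered what sits on the phenyl, whereas here the group on the carbonyl carbon itself changes: benzylamino, with its nitrogen and hydrogen-bond donor, gives a number 21 percentage points higher from compound 3 to compound 4 (beyond the scatter) and a number 17 percentage points higher from compound 2 to compound 4 (beyond the scatter) in this assay. This replacement reaches the level of the 2-methylphenyl compound, with a number 4 percentage points higher from compound 1 to compound 4 (within the scatter) so that these two groups cannot be ranked against each other. No measured evidence on the compounds explains this rise.

The compounds shown leave open whether the rise belongs to the nitrogen or to the extra carbon of benzylamino, which a phenylamino or a benzyl group on the carbonyl carbon would help to separate. Also open, from the compounds shown here alone, is how a methyl or a methoxy on the ring of benzylamino would act.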